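Chain swap on a lactone-free reading: compound 3 to compound 4

The compounds below may be only part of what the source reports. "The series", "measured", "known", "first", "only" and "open" are said of these compounds alone.

Measured so far:
Compound 1 `COCCCCCCCCCCCCCCC/C=C1/CC(CO)(COC(=O)C(C)(C)C)OC1=O` gives 2.13 ug/mL
Compound 2 `CCCCCCCCC(O)CCCCCC/C=C1\CC(CO)(COC(=O)C(C)(C)C)OC1=O` gives > 10 ug/mL (a limit of the assay)
Compound 3 `CCCCCOCCCCCCC/C=C1\CC(CO)(COC(=O)C(C)(C)C)OC1=O` gives 2.99 ug/mL

In a functional assay on SK-MEL-5 cells (Homo sapiens) for antiproliferative activity (on this read-out lower numbers stand for stronger inhibition of growth and higher numbers for weaker inhibition of growth), compound 3 gives 2.99 ug/mL and compound 1 gives 2.13 ug/mL as two values within the scatter of each other. Compound 2 gives > 10 ug/mL as a limit of the assay and not a number.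

The unmeasured compound 4 `CC(=O)OCCCCCCCCCCCCCCC/C=C1\CC(CO)(COC(=O)C(C)(C)C)OC1=O` differs from compound 3 in one place. The difference is 8-acetoxyoctyl in place of pentyloxy on a saturated chain carbon, seven bonds along the chain from a double-bonded chain carbon and it puts 8-acetoxyoctyl in place of pentyloxy on a saturated chain carbon, seven bonds along the chain from a double-bonded chain carbon.

For the measured compounds named here, one measured step concerns this stretch of chain, an at least 3.3-fold lower number from compound 2 to compound 3 (0.52 log units; beyond the scatter) and it lies beyond the scatter. It removes the hydroxyl of 1-hydroxynonyl. Compound 4 has no hydroxyl on its chain either, so it resembles compound 3 at 2.99 ug/mL and compound 1 at 2.13 ug/mL in that respect. No acetoxy chain has been measured, so the expected range is wide. The expected result is a 1.2-fold higher number from compound 3 to compound 4 (0.07 log units; within the scatter) in this assay and that means no change beyond the scatter. For compound 4 the estimated value is 3.5 ug/mL with an expected range from 1.3 ug/mL to 10 ug/mL in this estimate.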

Compound 4, concentration for 50% growth inhibition: 5.62 ug/mL
For compound 4 the middle estimate is 1.6-fold (0.21 log units) below the measured one; the measured number falls inside the stated range.
By their numbers in this assay, from the lowest: compounds 1, 3 and 4 (each within the scatter of the next, the first and the last beyond it). At a limit, above all of these: compound 2.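

In this assay, putting 8-acetoxyoctyl in place of pentyloxy on a saturated chain carbon, seven bonds along the chain from a double-bonded chain carbon, gives a 1.9-fold higher number from compound 3 to compound 4 (0.27 log units; within the scatter). This place in the chain therefore accepts a much larger group with an ester at its end, and the ether oxygen of pentyloxy is not needed there for growth inhibition to stay within the scatter of compound 3. Nothing shown here gives a cause for this step.

As far as these compounds go, what remains open is how much of this result belongs to the acetoxy end and how much to the length of the group, and an unbranched octyl group at this place would begin to separate the two. A carboxylic acid or an amine at the end of the same chain would show whether this stretch accepts such end groups as readily as it accepts the acetoxy group of compound 4.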